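Swapping the Aryl Group on a Saturated Ring Carbon

The compounds below may be only part of what the source reports. "The series", "measured", "known", "first", "only" and "open" are said of these compounds alone.

Among the compounds with values here, in a functional assay on WM 266-4 cells (Homo sapiens) for antiproliferative activity, read by MTT assay, with a stated time of 24 h (on this read-out higher numbers stand for weaker inhibition of growth and lower numbers for stronger inhibition of growth), compound 2 `COc1ccc(C2CC(c3ccc4c(c3)OCCO4)=NN2c2ccccc2)cc1OC` gives 2160 nM, the only actual number available in this small series. Compound 1 `c1ccc(N2N=C(c3ccc4c(c3)OCCO4)CC2c2ccco2)cc1` reads > 100000 nM, which is a limit of the assay and not a number.

The next compound, compound 3 `Ic1ccc(C2CC(c3ccc4c(c3)OCCO4)=NN2c2ccccc2)cc1`, carries 4-iodophenyl in place of the 3,4-dimethoxyphenyl of compound 2, on the same saturated ring carbon: 4-iodophenyl in place of 3,4-dimethoxyphenyl on a saturated ring carbon. Within the data shown here, one measured step bears on this site, an at least 46-fold lower number from compound 1 to compound 2 (1.66 log units; beyond the scatter). It shows that a change at this carbon can be large, but it concerns furan-2-yl and offers no direct measure of 4-iodophenyl. Like compound 2 at 2160 nM, compound 3 keeps a six-membered aromatic ring of carbon only at this site, so it is expected to stay in the same region rather than weaken as far as the furan-2-yl compound. The expected change is small, a 1.4-fold lower number from compound 2 to compound 3 (0.16 log units; within the scatter), with no clear shift beyond the scatter. For compound 3 the estimate is 1500 nM, with an expected range of 300 nM to 9000 nM.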

Compound 3, concentration for 50% growth inhibition: 3470 nM
Compound 3: middle estimate off by 2.3-fold (0.36 log units), on the low side, and the stated range covers the measured number.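

In this assay, 4-iodophenyl in place of 3,4-dimethoxyphenyl on the saturated ring carbon gives a 1.6-fold higher number from compound 2 to compound 3 (0.21 log units; within the scatter), so compound 2 and compound 3 cannot be told apart here, although 3,4-dimethoxyphenyl has 2 hydrogen-bond acceptors and 4-iodophenyl has 0. The comparison with furan-2-yl gives an at least 28-fold lower number from compound 1 to compound 3 (1.45 log units; beyond the scatter), so the large gap seen earlier no longer rests on 3,4-dimethoxyphenyl alone: it now holds for two different groups that each carry a six-membered aromatic ring of carbon only. The reading for compound 1 is a limit and not a number, and the true size of this gap stays unknown: the limit of > 100000 nM in this assay, at which 1 of the 3 values shown sits.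

The compounds shown leave open whether an unsubstituted phenyl, a pyridine ring or a saturated cyclohexyl group at this carbon would read like compound 2 and compound 3 or like compound 1. They also do not tell whether an aromatic ring is needed here at all, as a methyl group or a longer alkyl chain at the same carbon would show.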